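Cyanobenzyl for Methoxybenzyl on a Methoxyphenyl Core

A few compounds are considered here, and "the series" means these few. Any claim that something is new, unique, unknown or untested is made for them only; others in the source may bear on it.

Measured compounds:
compound 1 `COc1cccc(CN(NC(=O)NCCCN2CCN(c3ccccc3OC)CC2)c2ccc(F)cc2)c1`: 5.9 nM
compound 2 `COc1ccccc1N1CCN(CCCNC(=O)NN(Cc2ccc(C#N)cc2)c2ccc(F)cc2)CC1`: 15 nM
compound 3 `COc1ccc(N(Cc2cccc(OC)c2)NC(=O)NCCCN2CCN(c3ccccc3OC)CC2)cc1`: 33 nM

All three were tested in an assay on CHO cells for displacement of a labelled ligand from D(4) dopamine receptor (Homo sapiens), read by radioligand binding; a higher number here means a weaker inhibitor, a lower number a stronger inhibitor. Compound 1 gives 5.9 nM, and compound 2 gives 15 nM. Compound 2 is obtained from compound 1 by one change, (4-cyanophenyl in place of 3-methoxyphenyl on a saturated chain carbon bound to a nitrogen on an aromatic ring), and this change gave a 2.5-fold higher number from compound 1 to compound 2 (0.41 log units; beyond the scatter).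

Compound 3 differs from compound 1 in a different way, (methoxy in place of fluoro on an aromatic carbon), and this change gave a 5.6-fold higher number from compound 1 to compound 3 (0.75 log units; beyond the scatter). Compound 3 thus has the highest number of the three in this assay.

Compound 4 `COc1ccc(N(Cc2ccc(C#N)cc2)NC(=O)NCCCN2CCN(c3ccccc3OC)CC2)cc1` has not yet been measured. It relates to compound 3 exactly as compound 2 relates to compound 1: the change is 4-cyanophenyl in place of 3-methoxyphenyl on a saturated chain carbon bound to a nitrogen on an aromatic ring. The place of the change is the same in both pairs, so this is the same change carried out on a different core; the two cores differ by methoxy in place of fluoro on an aromatic carbon.

Within the data shown here, only one measured example of this change exists, the pair of compound 1 and compound 2, so the expectation for compound 4 rests on that single step. Because the change gave a 2.5-fold higher number from compound 1 to compound 2 (0.41 log units; beyond the scatter), compound 4 is expected to show a step of about a 2.4-fold higher number from compound 3 to compound 4 (0.38 log units; beyond the scatter) from compound 3 in this assay. With the value of compound 3 as the starting point, compound 4 is estimated at 80 nM, with a likely range from 30 nM to 220 nM.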

Compound 4, inhibition constant: 16 nM
For compound 4 the middle estimate is 5.0-fold (0.70 log units) above the measured one, outside the stated range (below it).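

In this assay, the swap from 3-methoxybenzyl to 4-cyanobenzyl gives a 2.1-fold lower number from compound 3 to compound 4 (0.31 log units; beyond the scatter), which runs in the opposite direction to the step seen on the core of compound 1, so this change does not carry from one core to the other as a fixed step: the same change on two cores in this assay, a 2.5-fold higher number (0.41 log units; beyond the scatter) from compound 1 to compound 2 and a 2.1-fold lower number (0.31 log units; beyond the scatter) from compound 3 to compound 4, 5.2-fold (0.72 log units) apart, beyond the scatter of two such steps

Read the other way, methoxy in place of fluoro on an aromatic carbon gives a 1.1-fold higher number from compound 2 to compound 4 (0.03 log units; within the scatter) when the 4-cyanobenzyl group is present, so the two changes do not simply add up and the effect of each depends on the other: the same change on two cores in this assay, a 5.6-fold higher number (0.75 log units; beyond the scatter) from compound 1 to compound 3 and a 1.1-fold higher number (0.03 log units; within the scatter) from compound 2 to compound 4, 5.2-fold (0.72 log units) apart, beyond the scatter of two such steps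

Among these compounds, these four compounds show that dependence for only two groups on two cores, and they do not show why the direction reverses or how the change would behave on any further core.

Still open, from the compounds shown here alone, is whether a plain benzyl group, with no substituent on its ring, would follow the 3-methoxybenzyl or the 4-cyanobenzyl pattern on these two cores. A chloro group in place of the fluoro or methoxy would likewise test whether the reversal is tied to these two cores or appears more widely in the series.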